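The source may hold more compounds than are shown below. What is called first, only, known or untested is meant among the compounds shown, and "the series" means these compounds.

Measured in a functional assay on MCF7 cells (Homo sapiens) for antiproliferative activity, read by MTT assay; a lower number here means a stronger inhibitor, a higher number a weaker inhibitor:
compound 1 `COc1ccc(-n2cc(COc3ccc(/C=C/C(=O)c4ccc5c(c4O)CCC(C)(C)O5)cc3)nn2)c([N+](=O)[O-])c1`: 73100 nM
compound 2 `Cc1ccc(-n2cc(COc3ccc(/C=C/C(=O)c4ccc5c(c4O)CCC(C)(C)O5)cc3)nn2)cc1Br`: "not active" (no number reported)

Compound 2 has no single number on this read-out. It is recorded only as "not active" (no number reported), so no step size can be calculated from it. Among the compounds with values here, compound 1 holds the only number so far, and that number reflects weak activity.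

The next compound to be tested is compound 3 `CC1(C)CCc2c(ccc(C(=O)/C=C/c3ccc(OCc4cn(Cc5ccc([N+](=O)[O-])cc5)nn4)cc3)c2O)O1`. The change is 4-nitrobenzyl in place of 3-bromo-4-methylphenyl on an aromatic nitrogen. It places 4-nitrobenzyl in place of 3-bromo-4-methylphenyl on an aromatic nitrogen of the five-membered aromatic ring with 3 nitrogen.

Compound 3 carries a nitro group, as compound 1 does, though the two differ in how the aromatic ring is attached. With compound 2 as the starting point, the expected step in this assay is a modest one towards greater potency, from no reported number to weak but measurable activity. This expectation rests on compound 1 at 73100 nM, and a second result with no number remains a real possibility.

The estimated value for compound 3 is 50000 nM, with an expected range of 15000 nM to 130000 nM.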

Compound 3, half-maximal inhibitory concentration: 17100 nM
For compound 3 the middle estimate is 2.9-fold (0.47 log units) above the measured one; measured number inside the range.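

In this assay, the group on the aromatic nitrogen of the five-membered ring now gives a readable comparison: 4-nitrobenzyl in place of 4-methoxy-2-nitrophenyl brings a 4.3-fold lower number from compound 1 to compound 3 (0.63 log units; beyond the scatter), so the number at this position responds to a change of group, which a single value could not show. Compound 2 remains recorded as "not active" with no number, so the steps linking it to compound 1 and compound 3 cannot be read, and 3-bromo-4-methylphenyl cannot be placed on the same scale. No measured data bearing on the reason for the step are available.

The step replaces a phenyl attachment with a benzyl attachment and removes the methoxy group at once, so the two changes cannot be weighed separately; 4-methoxy-2-nitrobenzyl on the same nitrogen would separate them. On these data alone, whether the nitro group itself matters also stays open, and an unsubstituted benzyl or a 4-aminobenzyl group at this place would address that question.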